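This account rests on a few compounds, and the source may have more. Where it says the series, first, only, none or still open, it means among the compounds named here.

Measured in a functional assay on MCF7 cells (Homo sapiens) for antiproliferative activity, with a stated time of 5 days; a higher number here means a weaker inhibitor, a lower number a stronger inhibitor:
- compound 1 `CCCc1ccc2[nH]c(-c3ccc(OC)cc3)c(C=C(C#N)C#N)c2c1`: 190 nM
- compound 2 `COc1ccc(-c2[nH]c3ccc(C(C)C)cc3c2C=C(C#N)C#N)cc1`: 310 nM

Among the compounds with values here, compound 2, at 310 nM, cannot be told apart from the only other measured compound, and neither can be ranked above the other. The next compound, compound 3 `CCCCCc1ccc2[nH]c(-c3ccc(OC)cc3)c(C=C(C#N)C#N)c2c1`, carries pentyl in place of isopropyl on an aromatic carbon, (pentyl in place of isopropyl on an aromatic carbon). Within the data shown here, only one measured step bears on this change, isopropyl in place of propyl at the same carbon, and it is small: a 1.6-fold higher number from compound 1 to compound 2 (0.21 log units; within the scatter). Among the measured compounds shown here, no compound with pentyl has been measured, so that step gives only weak guidance and the range must stay wide. The step expected in this assay is a 1.0-fold lower number from compound 2 to compound 3 (0.01 log units; within the scatter), which means no expected change beyond the scatter, in either direction. For compound 3 the estimated value is 300 nM, with an expected range from 100 nM to 900 nM.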

Compound 3, half-maximal inhibitory concentration: 76 nM
For compound 3 the middle estimate is 3.9-fold (0.60 log units) above the measured one, outside the stated range (below it).
By their numbers in this assay, from the lowest: compound 3; then compounds 1 and 2 (each within the scatter of the next).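

In (this assay), the alkyl group on this aromatic carbon now makes a measurable difference: pentyl in place of isopropyl gives (a 4.1-fold lower number from compound 2 to compound 3 (0.61 log units; beyond the scatter)), whereas the earlier exchange of propyl for isopropyl stayed within the scatter. Compound 3 also separates from the propyl compound, as ethyl in place of hydrogen on a saturated chain carbon, three bonds along the chain from an aromatic carbon, gives (a 2.5-fold lower number from compound 1 to compound 3 (0.40 log units; beyond the scatter)), so the gain is not confined to the comparison with isopropyl. Nothing shown accounts for why compound 3 gives the lowest number of the three.

The compounds shown leave open whether a longer chain, such as heptyl or nonyl, would lower the number further or reverse the step. They also leave open how an amine or a carboxylic acid at the end of the pentyl chain would compare.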